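Cyclohexyl for ethyl at the benzylic ether oxygen

A few compounds are considered here, and "the series" means these few. Any claim that something is new, unique, unknown or untested is made for them only; others in the source may bear on it.

Three compounds sharing one core have numbers in an assay on HEK293 cells for agonist activity at transient receptor potential cation channel subfamily M member 8 (Homo sapiens), read by fluorescence and calcium flux, with a stated time of 5 min; a higher number here means that more compound is needed for the effect, a lower number that less compound is needed. Compound 1 `C=CCc1cc(OC)c(OC(C)C(OCC)c2ccc(O)c(OC)c2)c(OC)c1`, drawn without configuration at either stereocentre, gives 332 nM, the second highest of the three. Compound 2 `C=CCc1cc(OC)c(O[C@@H](C)[C@@H](OCC)c2ccc(O)c(OC)c2)c(OC)c1` gives 87 nM, and compound 3 `C=CCc1cc(OC)c(O[C@H](C)[C@H](OCC)c2ccc(O)c(OC)c2)c(OC)c1` gives 583 nM. Going by the values given here, the steps of a 3.8-fold lower number from compound 1 to compound 2 (0.58 log units; beyond the scatter) and a 6.7-fold higher number from compound 2 to compound 3 (0.83 log units; beyond the scatter) are beyond the scatter, while a 1.8-fold higher number from compound 1 to compound 3 (0.24 log units; within the scatter) is not; the only difference in each pair is configuration, as the fact that one of compounds 1 and 2 is drawn with a defined configuration and the other without, at the place where they differ, the fact that one of compounds 1 and 3 is drawn with a defined configuration and the other without, at the place where they differ and the fact that compounds 2 and 3 differ only in the configuration as drawn show.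

Compound 4 `C=CCc1cc(OC)c(OC(C)C(OC2CCCCC2)c2ccc(O)c(OC)c2)c(OC)c1` is compound 1 with cyclohexyl in place of ethyl on an oxygen on a saturated carbon, configuration again undefined. Among the compounds with values here, none of the measured steps touches this position: all three concern configuration alone, so they give no direction for the ether change. The expected step of a 1.2-fold higher number from compound 1 to compound 4 (0.08 log units; within the scatter) is therefore set close to no change, with a wide range to cover an unanchored substitution. For compound 4 the estimate in this assay is 400 nM, expected to lie between 80 nM and 2500 nM.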

Compound 4, half-maximal effective concentration: 54 nM
For compound 4 the middle estimate is 7.4-fold (0.87 log units) above the measured one; the whole stated range lies above it.
By their numbers in this assay, from the lowest: compounds 4 and 2 (each within the scatter of the next); then compounds 1 and 3 (each within the scatter of the next).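

The position on an oxygen on a saturated carbon responds to the group it carries: in this assay, cyclohexyl in place of ethyl gives a 6.1-fold lower number from compound 1 to compound 4 (0.79 log units; beyond the scatter) with configuration undefined in both compounds. Going by these compounds alone, the earlier steps concerned configuration alone, so this is the first reading on the ether group itself, and it shows that the ring is accepted here and that less compound is needed with it than with ethyl. Nothing measured in this set bears on why the number falls.

Going by these compounds, compounds 1 and 4 are both drawn without configuration, so the size of this step within a single defined stereoisomer remains open. Also open, on these data alone, is whether the trend holds for a phenyl ring, a smaller cyclopropyl ring or a chain ending in an amine at this oxygen.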